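The source may hold more compounds than are shown below. What is called first, only, known or untested is meant among the compounds shown, and "the series" means these compounds.

Measured compounds:
- Compound 1 `COc1ccccc1-c1sc(N)c(C(=O)c2ccc(Cl)cc2)c1CC(C)(C)C` gives 1% in an assay on CHO cells for displacement of a labelled ligand from adenosine receptor A1 (Homo sapiens), read by scintillation counting, tested at 10 uM; a lower number here means less inhibition, a higher number more inhibition at the concentration tested (going by the name of the read-out)
- Compound 2 `COc1ccc(-c2sc(N)c(C(=O)c3ccc(Cl)cc3)c2CC(C)(C)C)cc1` gives 1% in this assay

Both measured compounds share the same core and differ only in the ring attached to it. Within the data shown here, neither shows meaningful displacement of the labelled ligand: compound 2 stands level with compound 1, and the one measured step, no change at the digits printed from compound 1 to compound 2 (within the scatter), lies within the ordinary scatter of this kind of measurement.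

Compound 3 `CC(C)(C)Cc1c(-c2cccs2)sc(N)c1C(=O)c1ccc(Cl)cc1` is the next compound in this series. Compared with compound 2 the change is thiophen-2-yl in place of 4-methoxyphenyl on an aromatic carbon. Among the measured compounds shown here, no measured step replaces a six-membered ring with a five-membered one, so the single known step bears on this change only loosely: it shows that moving a methoxy group around the phenyl ring left the read-out unmoved at the bottom of the scale.

For compound 3 the expectation is therefore a read-out at the same low level, with a step of about a number 2 percentage points higher from compound 2 to compound 3 (within the scatter), no change beyond the scatter, because no change at the digits printed from compound 1 to compound 2 (within the scatter) gave no movement. The estimated value for compound 3 in this assay is 3%, within a range from 0% to 15%.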

Compound 3, a percentage reported as inhibition, at one concentration (the size of the read-out at that concentration, not a potency): 1%
Compound 3: middle estimate off by 2 percentage points, on the high side; the measured number falls inside the stated range.
By their numbers in this assay, from the lowest: compounds 1, 2 and 3 (each within the scatter of the next).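

Replacing the six-membered 4-methoxyphenyl with the smaller five-membered thiophen-2-yl, on the aromatic carbon next to the ring sulfur, gives no change at the digits printed from compound 2 to compound 3 (within the scatter) in this assay. Set against the other methoxy compound, the same ring gives no change at the digits printed from compound 1 to compound 3 (within the scatter). Among these compounds, the earlier pair showed only that moving a methoxy group around a phenyl ring left the read-out at the bottom of the scale, whereas this result extends that to a change of ring size, a sulfur atom in the ring and the loss of the methoxy group; still, a read-out this close to zero cannot separate these rings from one another, and nothing available accounts for the flat result.

Still open, as far as these compounds go, is whether any group on this carbon can lift the read-out off the bottom of the scale, such as an amine, a carboxylic acid or a longer alkyl chain in place of the ring. From the compounds shown here alone, all three compounds also carry the same neopentyl and (4-chlorophenyl)carbonyl groups, so what a change at either of those places would do remains unknown.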